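The source may report more compounds than this note shows. Statements on the series, on what has been measured and on what is new or still open speak of the compounds shown alone.

Compound 1 `CCCCNc1nc(N)nc2c1CN(Cc1ccccc1)CC2` gives the lowest of the two numbers in an assay on HEK293 cells for agonist activity at Toll-like receptor 8 (Homo sapiens), read by a luciferase reporter, with a stated time of 6 h (a lower number here means that less compound is needed, a higher number that more compound is needed for the effect), at 0.06 uM. Compound 2 `CCCCNc1nc(N)nc2c1CNCC2`, with hydrogen in place of benzyl on an amine nitrogen in a ring, gives 7.2 uM in this assay, and the step of a 120-fold higher number from compound 1 to compound 2 (2.08 log units; beyond the scatter) is the only measured one. Compound 3 `CCCCNc1nc(N)nc2c1CN(Cc1ccc(-c3ccccc3)cc1)CC2` differs from compound 1 by phenyl in place of hydrogen on an aromatic carbon. Among the measured compounds shown here, no measured step alters the benzyl group itself; the step from compound 1 to compound 2 shows only how large the loss is on removing it, not the direction of extending it. Compound 3 is therefore expected to stay near compound 1, a step of no change at the digits printed from compound 1 to compound 3 (within the scatter), with an estimate of 0.06 uM between 0.015 uM and 0.3 uM.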

Compound 3, minimum effective concentration: 0.5 uM
For compound 3 the middle estimate is 8.3-fold (0.92 log units) below the measured one; the measured number lies above the stated range.
By their numbers in this assay, from the lowest: compound 1; then compound 3; then compound 2.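

Adding phenyl on this aromatic carbon, para to a large group, is not neutral in this assay, giving an 8.3-fold higher number from compound 1 to compound 3 (0.92 log units; beyond the scatter). Extending the benzyl group therefore carries a measurable cost, although this modest step is smaller than the large 120-fold higher number from compound 1 to compound 2 (2.08 log units; beyond the scatter) seen on removing benzyl. Nothing on hand explains the loss.

Going by these compounds, it remains open whether a smaller group at this place, such as methyl, methoxy or fluorine, would keep the number of compound 1. On these data alone, a longer chain between the ring nitrogen and the phenyl ring also remains untested here.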